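A few compounds are considered here, and "the series" means these few. Any claim that something is new, unique, unknown or untested is made for them only; others in the source may bear on it.

Series notes. In an assay on isolated protein for inhibition of ubiquitin carboxyl-terminal hydrolase 7 (Homo sapiens), with stated times of 30 min and 2 h (a lower number here means a stronger inhibitor, a higher number a weaker inhibitor), compound 1 `Cn1nc2c(=O)n(CC3(O)CCN(Cc4ccc(-c5ccoc5)cc4Cl)CC3)cnc2c1-c1ccc(CN)cc1` gives 177 nM. Compound 2 `Cc1ccc(-c2ccc(CN3CCC(O)(Cn4cnc5c(-c6ccc(CN)cc6)n(C)nc5c4=O)CC3)c(Cl)c2)s1` gives 101 nM, and compound 3 `Cn1nc2c(=O)n(CC3(O)CCN(Cc4ccc(-c5cnco5)cc4Cl)CC3)cnc2c1-c1ccc(CN)cc1` gives 71.6 nM, the lowest of the three numbers shown. The steps at this position were a 2.5-fold lower number from compound 1 to compound 3 (0.39 log units; beyond the scatter), a 1.4-fold lower number from compound 2 to compound 3 (0.15 log units; within the scatter) and a 1.8-fold lower number from compound 1 to compound 2 (0.24 log units; within the scatter). Compound 4 `Cn1nc2c(=O)n(CC3(O)CCN(Cc4ccc(C5CCCO5)cc4Cl)CC3)cnc2c1-c1ccc(CN)cc1` differs from compound 3 by oxolan-2-yl in place of 1,3-oxazol-5-yl on an aromatic carbon. For the measured compounds named here, the group that enters is a non-aromatic ring, so none of the measured steps covers this change closely; the earlier swaps between aromatic five-membered rings at this position moved the number by at most a modest amount. A step toward a higher number is expected for compound 4, a 2.1-fold higher number from compound 3 to compound 4 (0.32 log units; beyond the scatter), with a wide range given the lack of a close precedent. The estimate for compound 4 in this assay is 150 nM, between 60 nM and 400 nM.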

Compound 4, half-maximal inhibitory concentration: 3820 nM
Compound 4: middle estimate off by 25-fold (1.41 log units), on the low side; measured number outside the range, above it.
By their numbers in this assay, from the lowest: compounds 3, 2 and 1 (each within the scatter of the next, the first and the last beyond it); then compound 4.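

At this position in this assay, a five-membered non-aromatic ring does not stand in for the aromatic ones: oxolan-2-yl gives a 53-fold higher number from compound 3 to compound 4 (1.73 log units; beyond the scatter) and a 38-fold higher number from compound 2 to compound 4 (1.58 log units; beyond the scatter) and also a 22-fold higher number from compound 1 to compound 4 (1.33 log units; beyond the scatter) against the three aromatic rings shown. Each of these steps is far larger than any step among compound 1, compound 2 and compound 3, so this change matters much more here than swaps between aromatic rings. No measurement at hand gives a reason for the loss.

With only one non-aromatic ring shown, it remains open whether the loss extends to other such rings or is particular to oxolan-2-yl. From the compounds shown here alone, how a pyridine ring, a morpholine ring or an open methoxyethyl chain would read at this position also remains open.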